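This account rests on a few compounds, and the source may have more. Where it says the series, first, only, none or still open, it means among the compounds named here.

Working notes on a small set of cyclic sulfonylguanidines sharing one core, tested in a functional assay (aorta) with Rattus norvegicus as the target; a higher number here means that more compound is needed for the effect, a lower number that less compound is needed.

Compound 1 `CC(C)NC1=NS(=O)(=O)c2cccnc2N1` in this assay gives 132 uM. Compound 2 `CCC(C)NC1=NS(=O)(=O)c2cccnc2N1` in this assay gives 50.9 uM. The two differ in one place:
methyl in place of hydrogen on a saturated chain carbon, two bonds along the chain from an amine nitrogen
Compound 3 `O=S1(=O)N=C(NCc2ccccc2)Nc2ncccc21` in this assay gives 21.9 uM, the lowest of the three measured numbers; its gap to compound 2 and its wider gap to compound 1 both lie beyond the scatter. The difference between the cores of compound 3 and compound 1 is not broken down here.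

Compound 4 `C[C@H](NC1=NS(=O)(=O)c2cccnc2N1)c1ccccc1` awaits measurement in this assay. It differs from compound 3 as follows:
methyl in place of hydrogen on a saturated chain carbon bound to an amine nitrogen and an aromatic carbon
Going by the values given here, this is the same kind of change as the one from compound 1 to compound 2, not the same: there the methyl entered on a saturated chain carbon two bonds along the chain from an amine nitrogen, here on a saturated chain carbon bound to an amine nitrogen and an aromatic carbon. Among the compounds with values here, the one measured precedent is a 2.6-fold lower number from compound 1 to compound 2 (0.41 log units; beyond the scatter), a modest step beyond the scatter. Within the data shown here, the estimated step here, a 1.7-fold lower number from compound 3 to compound 4 (0.23 log units; within the scatter), is kept smaller than that precedent, since the place is not the same and the series holds no second example to lean on. Compound 4 is therefore expected to give 13 uM, with a plausible range from 5 uM to 40 uM.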

Compound 4, concentration for half-maximal effect: 65.2 uM
Compound 4: the middle estimate sits 5.0-fold (0.70 log units) below what was measured, and the stated range ends below it.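

In this assay, methyl in place of hydrogen on a saturated chain carbon bound to an amine nitrogen and an aromatic carbon gives a 3.0-fold higher number from compound 3 to compound 4 (0.47 log units; beyond the scatter), which runs against the direction of the earlier step, a 2.6-fold lower number from compound 1 to compound 2 (0.41 log units; beyond the scatter). Within this series, then, methyl in place of hydrogen does not carry from one side chain to another as a fixed step, and its direction does not carry either: the same change on two cores in this assay, a 2.6-fold lower number (0.41 log units; beyond the scatter) from compound 1 to compound 2 and a 3.0-fold higher number (0.47 log units; beyond the scatter) from compound 3 to compound 4, 7.7-fold (0.89 log units) apart, beyond the scatter of two such steps What this does not show is which difference decides the outcome: the two steps differ in the place of the methyl as well as in the rest of the side chain, and with a single pair on each side, these cannot be separated and no rule for further members can be drawn.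

The compounds shown leave open how the mirror-image form of compound 4 would read in this assay, and so whether the higher number of compound 4 belongs to the methyl as such or to its particular configuration. They also leave open whether an ethyl in place of that methyl, or a longer chain carrying the aromatic ring, would follow compound 4 or compound 2.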